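A single chloro added to the phenol ring of compound 3

The source may report more compounds than this note shows. Statements on the series, on what has been measured and on what is new or still open speak of the compounds shown alone.

Compound 3 `COC(=O)/C=C/c1ccc(NCc2ccccc2O)cc1` gives 7170 nM in a functional assay on HeLa cells (Homo sapiens) for antiproliferative activity, read by WST assay, with a stated time of 72 h (on this read-out higher numbers stand for weaker inhibition and lower numbers for stronger inhibition), the lowest of the three numbers in hand. Compound 1 `COC(=O)/C=C/c1ccc(NCc2cc([N+](=O)[O-])ccc2O)cc1` gives 16000 nM, and compound 2 `COC(=O)/C=C/c1ccc(NCc2cc(Cl)cc(Cl)c2O)cc1` gives 25900 nM. Among the compounds with values here, the only measured step that changes one place, a 2.2-fold lower number from compound 1 to compound 3 (0.35 log units; beyond the scatter), is modest. Compound 4 `COC(=O)/C=C/c1ccc(NCc2cc(Cl)ccc2O)cc1` differs from compound 3 by chloro in place of hydrogen on an aromatic carbon, meta to a large group and para to the hydroxy group. Within the data shown here, no measured step isolates a single chloro; compound 2, which carries two chloro groups, shows a higher number than compound 3, so a somewhat higher number is expected for compound 4, about the size of a 1.7-fold higher number from compound 3 to compound 4 (0.22 log units; within the scatter). For compound 4 in this assay the estimate is 12000 nM, expected between 6000 nM and 25000 nM.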

Compound 4, half-maximal inhibitory concentration: 8560 nM
Compound 4: the middle estimate sits 1.4-fold (0.15 log units) above what was measured; low and high end bracket the measured number.
By their numbers in this assay, from the lowest: compounds 3, 4, 1 and 2 (each within the scatter of the next, the first and the last beyond it).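

Chloro in place of hydrogen at this carbon, para to the hydroxy group, stays within the scatter in this assay (a 1.2-fold higher number from compound 3 to compound 4 (0.08 log units; within the scatter)), so a single chloro here is accommodated. Chloro and nitro at this carbon also cannot be separated (a 1.9-fold lower number from compound 1 to compound 4 (0.27 log units; within the scatter)), whereas the step that removes the other chloro is beyond the scatter (a 3.0-fold lower number from compound 2 to compound 4 (0.48 log units; beyond the scatter)) and is the larger one. No measurement in hand offers a reason for these steps.

On these data alone, whether an amine or a carboxylic acid at this carbon would leave the number within the scatter remains open. So does the role of the methyl ester.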